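Swapping the Bromophenoxy Ether for a Methylanilino Chain

The source may hold more compounds than are shown below. What is called first, only, known or untested is meant among the compounds shown, and "the series" means these compounds.

Measured so far in a functional assay (aorta) with Oryctolagus cuniculus as the target; a higher number here means weaker binding, a lower number tighter binding:
compound 1 `COc1cc(C(=O)O)ccc1OCCCN1CCC(C(c2ccc(F)cc2)c2ccc(F)cc2)CC1` gives 79.4 nM
compound 2 `Fc1ccc(C(c2ccc(F)cc2)C2CCN(CCCOc3ccc(Cl)cc3)CC2)cc1` gives 2 nM
compound 3 `Fc1ccc(C(c2ccc(F)cc2)C2CCN(CCCOc3ccc(Br)cc3)CC2)cc1` gives 1.59 nM

Compound 3 has the lowest number of the three. Compound 2 sits close to it, since a 1.3-fold lower number from compound 2 to compound 3 (0.10 log units; within the scatter), while compound 1 lies far off, since a 50-fold lower number from compound 1 to compound 3 (1.70 log units; beyond the scatter). The large steps seen so far, a 40-fold lower number from compound 1 to compound 2 (1.60 log units; beyond the scatter) and a 50-fold lower number from compound 1 to compound 3 (1.70 log units; beyond the scatter), both come from exchanging the 4-carboxy-2-methoxyphenyl for a halophenyl on the same oxygen; the halogen swap itself, a 1.3-fold lower number from compound 2 to compound 3 (0.10 log units; within the scatter), changes little.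

Compound 4 `CN(CCCN1CCC(C(c2ccc(F)cc2)c2ccc(F)cc2)CC1)c1ccccc1` differs from compound 3 as follows: methyl(phenyl)amino in place of 4-bromophenoxy on a saturated chain carbon, three bonds along the chain from an amine nitrogen in a ring. For the measured compounds named here, no measured step covers this exchange of the oxygen for a methylated nitrogen or the loss of the bromine, so the expectation rests only on the observation that the shared core tolerates a halophenyl well and that the far end of this chain can matter greatly. A moderate weakening is estimated, though a result near compound 3 cannot be excluded. Compound 4 is therefore expected to give about 5 nM, between 1.2 nM and 30 nM, an expected step of a 3.1-fold higher number from compound 3 to compound 4 (0.50 log units; beyond the scatter).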

Compound 4, dissociation constant: 2 nM
Compound 4: middle estimate off by 2.5-fold (0.40 log units), on the high side; measured number inside the range.
By their numbers in this assay, from the lowest: compounds 3, 2 and 4 (each within the scatter of the next); then compound 1.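

Among these compounds, the far end of the chain accepts a nitrogen link as readily as an oxygen link: methyl(phenyl)amino in place of 4-bromophenoxy gives a 1.3-fold higher number from compound 3 to compound 4 (0.10 log units; within the scatter), and in place of 4-chlorophenoxy it gives no change at the digits printed from compound 2 to compound 4 (within the scatter) in this assay. Methyl(phenyl)amino in place of 4-carboxy-2-methoxyphenoxy gives a 40-fold lower number from compound 1 to compound 4 (1.60 log units; beyond the scatter), so the large step away from compound 1 needs neither a halogen nor the ether oxygen. There is no outside measurement to explain why these groups give such similar numbers.

Going by these compounds, it remains open whether a bromine on the ring of the methyl(phenyl)amino group, or a hydrogen in place of its methyl, would move the number. A carboxylic acid on that same ring could show whether the acid alone accounts for the much higher number of compound 1.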